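Swapping furan for pyrimidine on the glycinamide tail

The source may hold more compounds than are shown below. What is called first, only, known or untested is meant among the compounds shown, and "the series" means these compounds.

Compound 1, `Cc1cc(C)cc(S(=O)(=O)c2c(C(=O)NC(C)C(=O)NC(C)c3ccncc3)[nH]c3ccc(Cl)cc23)c1`, in an ADME assay on MT4 cells (Homo sapiens) for cytotoxicity, read by MTT assay; on this read-out higher numbers stand for lower toxicity in this test and lower numbers for higher toxicity in this test: 21900 nM
Compound 2, `Cc1cc(C)cc(S(=O)(=O)c2c(C(=O)NC(C)C(=O)NCc3ccccc3F)[nH]c3ccc(Cl)cc23)c1`, in this assay: 23300 nM
Compound 3, `Cc1cc(C)cc(S(=O)(=O)c2c(C(=O)NCC(=O)NCc3ccco3)[nH]c3ccc(Cl)cc23)c1`, in this assay: > 50000 nM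

Compound 3 stands apart from the other two: its value in this assay is not a number but a limit of the assay, (the limit of > 50000 nM in this assay, at which 1 of the 3 values shown sits). Compound 4, `Cc1cc(C)cc(S(=O)(=O)c2c(C(=O)NCC(=O)NCc3ccncn3)[nH]c3ccc(Cl)cc23)c1`, differs from compound 3 in one place, (pyrimidin-4-yl in place of furan-2-yl on a saturated chain carbon bound to an amide-type nitrogen). Within the data shown here, no measured pair shows this same exchange. Among the measured compounds shown here, the only measured step, a 1.1-fold higher number from compound 1 to compound 2 (0.03 log units; within the scatter), changes a group on an amide-type nitrogen as well, and it lies within the scatter. On that slim basis, and with compound 3 already at the limit, no step beyond the scatter is expected from compound 3 to compound 4, so the estimated step is a number no higher from compound 3 to compound 4 (the limit leaves the size open). Compound 4 is therefore expected to give about 50000 nM in this assay, with a plausible range from 25000 nM to 100000 nM, and a fair chance that the assay again reports only a limit.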

Compound 4, half-maximal cytotoxic concentration: > 48800 nM
Compound 4 was reported as a limit; the forecaster's own chance of this, stated with the estimate: 60%; the middle value lies beyond the limit too.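

In this assay compound 3 is reported only as a limit, > 50000 nM. Among these compounds, compound 4 is likewise reported only as a limit, > 48800 nM, so no step from one to the other can be read. The compounds shown leave open whether pyrimidin-4-yl in place of furan-2-yl shifts this read-out at all, and in which direction.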